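The source may hold more compounds than are shown below. What is called first, only, known or untested is meant among the compounds shown, and "the series" means these compounds.

Measured so far in a functional assay on HEK293 cells for agonist activity at Free fatty acid receptor 1 (Homo sapiens), read by calcium flux; on this read-out higher numbers stand for an effect only at larger amounts of compound and lower numbers for an effect already at smaller amounts: compound 1 `CCCCOc1ccc(C(CC(=O)O)c2ccccc2)cc1` gives 1.2 uM; compound 2 `COCCCOc1ccc(C(CC(=O)O)c2ccccc2)cc1` gives 7.58 uM.

Compound 2 holds the higher of the two numbers; the step of a 6.3-fold higher number from compound 1 to compound 2 (0.80 log units; beyond the scatter) separates them and lies beyond the scatter. Compound 3 `C=C(C)CCOc1ccc(C(CC(=O)O)c2ccccc2)cc1` differs from compound 2 by 1-methylethenyl in place of methoxymethyl on a saturated chain carbon, two bonds along the chain from an oxygen on an aromatic ring. For the measured compounds named here, the only measured step that bears on this is a 6.3-fold higher number from compound 1 to compound 2 (0.80 log units; beyond the scatter), where an ether oxygen entering the chain raised the number. Compound 3 takes that oxygen out again while keeping a chain of the same length, so a drop back toward compound 1 is expected, of about a 5.1-fold lower number from compound 2 to compound 3 (0.70 log units; beyond the scatter). Compound 3 is therefore estimated at 1.5 uM, within 0.5 uM to 4.5 uM.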

Compound 3, concentration for half-maximal effect: 2.71 uM
Compound 3: middle estimate off by 1.8-fold (0.26 log units), on the low side, and the stated range covers the measured number.
By their numbers in this assay, from the lowest: compound 1; then compound 3; then compound 2.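

With 1-methylethenyl in place of methoxymethyl, the read-out in this assay shows a 2.8-fold lower number from compound 2 to compound 3 (0.45 log units; beyond the scatter), so the number falls when the chain oxygen leaves and the chain length stays. For the compounds shown here, the return is only partial: a 2.3-fold higher number from compound 1 to compound 3 (0.35 log units; beyond the scatter) remains, so the ether oxygen is not the only change at this place that raises the number. Nothing measured here explains either step.

The compounds shown do not separate the double bond from the branching within 1-methylethenyl. On these data alone, how an isopropyl group or a longer chain would read at this place remains open.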